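Swapping One Aryl Group on a Shared Core

This account rests on a few compounds, and the source may have more. Where it says the series, first, only, none or still open, it means among the compounds named here.

Compound 2 `COc1ccc(-c2nc(-c3ccccc3)c(-c3ccc4c(c3)NC(=O)CO4)[nH]2)cc1` stands level with compound 1 `O=C1COc2ccc(-c3[nH]c(-c4ccc(F)cc4)nc3-c3ccccc3)cc2N1` and compound 3 `O=C1COc2ccc(-c3nn(-c4ccc(Cl)cc4)cc3-c3ccccc3)cc2N1` in a functional assay on MV4-11 cells (Homo sapiens) for cytotoxicity, read by colorimetric assay and MTT assay, with a stated time of 3 days, tested at 1 uM; a lower number here means a stronger effect, a higher number a weaker effect of the compound at the concentration tested: compound 2 gives 108%, compound 1 gives 108%, and compound 3 gives 108%. Compound 4 `O=C1COc2ccc(-c3[nH]c(-c4ccc(Cl)cc4Cl)nc3-c3ccccc3)cc2N1` differs from compound 2 by 2,4-dichlorophenyl in place of 4-methoxyphenyl on an aromatic carbon. Among the measured compounds shown here, only one measured step touches this position: no change at the digits printed from compound 1 to compound 2 (within the scatter), so exchanging the group on that carbon left the read-out untouched there. For the measured compounds named here, no measured pair shows chlorine entering at this position, so the expectation rests on that single flat step. Compound 4 is therefore expected to show no step beyond the scatter, a number 3 percentage points lower from compound 2 to compound 4 (within the scatter). The estimated value for compound 4 is 105%, within a range of 85% to 125%.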

Compound 4, a percentage reported as activity, at one concentration (the size of the read-out at that concentration, not a potency): 109%
Estimate against measurement, compound 4: 4 percentage points below, and the stated range covers the measured number.
By their numbers in this assay, from the lowest: compounds 1, 2, 3 and 4 (each within the scatter of the next).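

In this assay, 2,4-dichlorophenyl in place of 4-methoxyphenyl leaves the read-out flat (a number 1 percentage points higher from compound 2 to compound 4 (within the scatter)), and so does 2,4-dichlorophenyl in place of 4-fluorophenyl (a number 1 percentage points higher from compound 1 to compound 4 (within the scatter)). This position on the shared core has now taken a ring with two chlorine atoms, with no step beyond the scatter at the concentration tested. No measurement here offers an explanation for this flat result. On these data alone, what an amine or a carboxylic acid would do at this carbon stays open, as does whether any group there can lower the number.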